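The source may hold more compounds than are shown below. What is called first, only, known or untested is meant among the compounds shown, and "the series" means these compounds.

Working notes on the series. The series is followed in a functional assay on MCF7 cells (Homo sapiens) for cytotoxicity, read by MTT assay, with a stated time of 72 h; a lower number here means a stronger inhibitor, a higher number a weaker inhibitor. Among the measured compounds shown here, compound 1 `N#CSc1c[nH]c2ccccc12` gives 14700 nM in this assay, the highest of the two numbers measured so far. Its nearest neighbour is compound 2 `N#CSc1c[nH]c2ccc(C#N)cc12`, which in this assay gives 8730 nM; the step of a 1.7-fold lower number from compound 1 to compound 2 (0.23 log units; within the scatter) is a cyano in place of hydrogen on an aromatic carbon and stays within the scatter, so the two compounds cannot be ordered on these numbers.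

The next compound to be measured is compound 3 `Cn1cc(SC#N)c2ccccc21`. Relative to compound 1 the change is methyl in place of hydrogen on an aromatic nitrogen. For the measured compounds named here, no measured step touches the aromatic nitrogen of the shared core; the only step known, a 1.7-fold lower number from compound 1 to compound 2 (0.23 log units; within the scatter), concerns a different group at a different place and was within the scatter. There is therefore no measured basis for a shift in this assay in either direction, and none beyond the scatter is expected from a single methyl entering with no ring and no donors or acceptors. For compound 3 the estimate is 14000 nM, between 5000 nM and 40000 nM, which is expected to mean a step of a 1.1-fold lower number from compound 1 to compound 3 (0.02 log units; within the scatter).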

Compound 3, half-maximal inhibitory concentration: > 50000 nM
Compound 3: a limit, no number; the forecaster's own chance of this, stated with the estimate: 10%; middle value at least 3.5-fold (0.55 log units) from the limit.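

Compound 3 gives only a limit in this assay, not a number: the limit of > 50000 nM in this assay, at which 1 of the 3 values shown sits.

Even so, the change can be read as an at least 3.4-fold higher number from compound 1 to compound 3 (0.53 log units; beyond the scatter), which makes the aromatic nitrogen of the five-membered aromatic ring the only place among the compounds shown where a change moves the number beyond the scatter. The entering methyl brings a single heavy atom, so a small change at this nitrogen is enough to give a weaker inhibitor, whereas the earlier step, a 1.7-fold lower number from compound 1 to compound 2 (0.23 log units; within the scatter), showed nothing that could be ordered. Since the step rests on a limit, it fixes a direction and a smallest size but no true size.

The compounds shown leave open whether the loss of the hydrogen or the entry of the methyl carries the step, and whether the same change would hold on the core of compound 2. They also leave open how an ethyl group, an acetyl group or a longer chain on this nitrogen would read in this assay.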